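The source may hold more compounds than are shown below. What is called first, only, known or untested is meant among the compounds shown, and "the series" means these compounds.

Measured compounds:
compound 1 `CCN(Cc1ccco1)C(=O)COc1ccc(C)cc1`: 489 nM
compound 2 `Cc1ccc(OCC(=O)N(Cc2cccs2)c2ccnn2C)cc1`: 422 nM
compound 3 `Cc1ccc(OCC(=O)N(Cc2cccs2)c2nccs2)cc1`: 2240 nM

In an assay on HEK293 cells for agonist activity at transient receptor potential cation channel subfamily M member 8 (Homo sapiens), read by fluorescence and calcium flux, with a stated time of 15 min (on this read-out lower numbers stand for an effect already at smaller amounts and higher numbers for an effect only at larger amounts of compound), compound 1 stands second highest of the three numbers; compound 2 sits within the usual scatter of it, while compound 3 lies clearly higher. Among the measured compounds shown here, the one step that differs in a single place is a 5.3-fold higher number from compound 2 to compound 3 (0.72 log units; beyond the scatter), where the group exchanged sits directly on the amide-type nitrogen rather than on the chain carbon beside it, so it speaks only indirectly to the question here.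

Compound 4 `CCN(Cc1ccccn1)C(=O)COc1ccc(C)cc1` has not yet been measured. Its change from compound 1 is pyridin-2-yl in place of furan-2-yl on a saturated chain carbon bound to an amide-type nitrogen. No measured pair alters the ring on this saturated chain carbon, so nothing shown says whether such an exchange moves the number. For the measured compounds named here, the only guide is that a ring swap at a neighbouring position produced a step of modest size, and the expectation is therefore a step of a 1.1-fold higher number from compound 1 to compound 4 (0.05 log units; within the scatter), which is no change beyond the scatter. Compound 4 is estimated at 550 nM, with a likely range from 200 nM to 1600 nM.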

Compound 4, half-maximal effective concentration: 16000 nM
Compound 4: middle estimate off by 29-fold (1.46 log units), on the low side; the measured number lies above the stated range.
By their numbers in this assay, from the lowest: compounds 2 and 1 (each within the scatter of the next); then compound 3; then compound 4.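

Among the compounds shown here, this is the first measured change of the ring on a saturated chain carbon bound to an amide-type nitrogen, and in this assay it gives a 33-fold higher number from compound 1 to compound 4 (1.51 log units; beyond the scatter), so the number here depends strongly on which ring is present. Furan-2-yl and pyridin-2-yl have the same counts of hydrogen-bond donors and acceptors, and neither carries a net charge, so those counts do not separate them, although the rings differ in size and in their hetero atom. No measurement here explains the step.

The compounds shown do not separate the effect of ring size from that of the hetero atom, as the two change together. A phenyl ring on the same chain carbon, a six-membered ring with no hetero atom, would be one way to pull the two apart.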